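Replacing the bromo substituent of compound 3 with methylcarbamoyl

The compounds below may be only part of what the source reports. "The series", "measured", "known", "first", "only" and "open" are said of these compounds alone.

Compound 1, `O=C(CCCCCCc1ccccc1)c1nc(C(=O)C(F)(F)F)co1`, gives 123 nM in an assay on HEK-293T cells for inhibition of diacylglycerol lipase-alpha (Homo sapiens), read by colorimetric assay; on this read-out lower numbers stand for stronger inhibition and higher numbers for weaker inhibition.
Compound 2, `CS(=O)(=O)c1coc(C(=O)CCCCCCc2ccccc2)n1`, gives 389 nM in this assay.
Compound 3, `O=C(CCCCCCc1ccccc1)c1nc(Br)co1`, reaches only the limit of this assay, > 10000 nM.

Compound 3 therefore stands at the weak end of the three measured compounds, its result being a limit and not a number (the limit of > 10000 nM in this assay, at which 1 of the 3 values shown sits). Compound 4, `CNC(=O)c1coc(C(=O)CCCCCCc2ccccc2)n1`, differs from compound 3 in one place: methylcarbamoyl in place of bromo on an aromatic carbon.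

Within the data shown here, two measured steps bear on this change, both leading into compound 3 and both large. The step of an at least 81-fold higher number from compound 1 to compound 3 (1.91 log units; beyond the scatter) and the step of an at least 25-fold higher number from compound 2 to compound 3 (1.41 log units; beyond the scatter) show that exchanging either the (trifluoromethyl)carbonyl or the methylsulfonyl group for bromo at this position costs a great deal of inhibition. Methylcarbamoyl, like those two groups, carries a double bond outside the aromatic ring and a hydrogen-bond acceptor where bromo carries none, so the reverse direction is expected here: going from compound 3 to compound 4 should give a large step toward lower numbers in this assay, though how far it falls between the bromo and the measured groups is uncertain.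

Compound 4 is therefore expected to show 1500 nM, in a range from 300 nM to 10000 nM, which amounts to an estimated step of an at least 6.6-fold lower number from compound 3 to compound 4 (0.82 log units; beyond the scatter).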

Compound 4, half-maximal inhibitory concentration: > 10000 nM
Compound 4 ended at the assay's limit (the forecaster's own chance of this, stated with the estimate: 25%); at least 6.6-fold (0.82 log units) between middle value and limit.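

The carbonyl on this aromatic carbon does not by itself carry the inhibition: methylamino in place of trifluoromethyl on that carbonyl carbon gives an at least 81-fold higher number from compound 1 to compound 4 (1.91 log units; beyond the scatter). Methylcarbamoyl also falls well short of methylsulfonyl, with an at least 25-fold higher number from compound 2 to compound 4 (1.41 log units; beyond the scatter), so among these compounds a double bond outside the aromatic ring and a hydrogen-bond acceptor at this position are not enough to keep inhibition. Compound 4 gives only a limit, as compound 3 does, so the step between them cannot be read and the bromo and methylcarbamoyl groups cannot be ranked in this assay: the limit of > 10000 nM in this assay, at which 2 of the 4 values shown sit.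

The compounds shown leave open how a methyl ester or a nitrile on this aromatic carbon would stand against the (trifluoromethyl)carbonyl and methylsulfonyl groups. They also leave open whether the amide hydrogen of methylcarbamoyl has any part in the loss, a question that a dimethylcarbamoyl group at the same place would address.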